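The source may hold more compounds than are shown below. What is called first, only, known or untested is meant among the compounds shown, and "the series" means these compounds.

Working notes on the series in a functional assay on SW480 cells (Homo sapiens) for cytotoxicity, read by MTT assay, with a stated time of 48 h; on this read-out lower numbers stand for stronger inhibition and higher numbers for weaker inhibition. Compound 1 (`COc1cc([C@@H]2C[C@]2(CO)C(=O)Nc2ccccc2Cl)cc(OC)c1OC`) gives 13200 nM, compound 2 (`COc1cc([C@@H]2C[C@]2(CO)C(=O)NCc2ccc(C)cc2)cc(OC)c1OC`) gives 26800 nM and compound 3 (`CCOC(=O)[C@]1(C(=O)NCc2ccc(C)cc2)C[C@H]1c1cc(OC)c(OC)c(OC)c1`) gives 36400 nM. Compound 2 holds the middle of the three numbers, though only its gap to compound 1 lies beyond the scatter. The change on the amide-type nitrogen is a 2.0-fold higher number from compound 1 to compound 2 (0.31 log units; beyond the scatter), and the change on the saturated ring carbon is a 1.4-fold higher number from compound 2 to compound 3 (0.13 log units; within the scatter).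

Compound 4 (`COc1cc([C@H]2C[C@@]2(CO)C(=O)NCc2ccc(C)cc2)cc(OC)c1OC`) is the mirror image of compound 2: the two compounds have the same atoms and bonds and differ only in configuration as drawn: 2 of 2 stereo elements differ (all stereocentres are inverted: mirror images); a stereocentre at a saturated ring carbon is drawn S in compound 2 and R in compound 4; a stereocentre at a saturated ring carbon is drawn S in compound 2 and R in compound 4. Neither measured step inverts a stereocentre, so neither gives a direction for this change. They show only the modest size of the steps seen so far. Going by the values given here, no mirror-image pair has been measured, so the expectation in this assay is no shift beyond the scatter, held with a wide margin on both sides. The expected change is a 1.0-fold lower number from compound 2 to compound 4 (0.01 log units; within the scatter). The estimate for compound 4 is 26000 nM, with an expected range of 11000 nM to 60000 nM.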

Compound 4, half-maximal inhibitory concentration: > 100000 nM
Compound 4 ended at the assay's limit; the forecaster's own chance of this, stated with the estimate: 10%; middle value at least 3.8-fold (0.58 log units) away from the limit.
By their numbers in this assay, from the lowest: compound 1; then compounds 2 and 3 (each within the scatter of the next). At a limit, above all of these: compound 4.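

Compound 4 gives > 100000 nM in this assay, and this is a limit of the assay, not a number. Inverting both stereocentres on the saturated ring carbons gives an at least 3.7-fold higher number from compound 2 to compound 4 (0.57 log units; beyond the scatter), so the series responds to configuration as well as to the substituents changed in the earlier steps. Since no atom or bond changes, this shift can be assigned to configuration alone because of the following: the fact that compounds 2 and 4 differ only in the configuration as drawn

Which of the two stereocentres carries the shift stays open, as would be tested by a compound with only one of them inverted. Also open, on these data alone, is whether the same dependence on configuration holds with the 2-chlorophenyl group on the amide-type nitrogen, or with a carboxylic acid in place of the hydroxymethyl on the saturated ring carbon.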